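A methyl group shifts on the dimethylphenyl ring

The compounds below may be only part of what the source reports. "The series", "measured", "known", "first", "only" and "open" are said of these compounds alone.

Of the compounds shown here, three sharing one core have been measured so far in a functional assay on PC-3 cells (Homo sapiens) for cytotoxicity, read by MTT assay, with a stated time of 48 h (on this read-out higher numbers stand for weaker inhibition and lower numbers for stronger inhibition), and their numbers lie close together. Compound 1 (`CC1(C)CCC[C@]2(C)[C@@H](CC[C@@](C)(O)/C=C/c3cncc4ccccc34)[C@](C)(O)CC[C@@H]12`) gives 3900 nM there, compound 2 (`Cc1cccc(/C=C/[C@](C)(O)CC[C@@H]2[C@@]3(C)CCCC(C)(C)[C@@H]3CC[C@@]2(C)O)c1C`) gives 3500 nM there, and compound 3 (`COc1cccc(/C=C/[C@](C)(O)CC[C@@H]2[C@@]3(C)CCCC(C)(C)[C@@H]3CC[C@@]2(C)O)c1OC`) gives 2900 nM there. Compound 2 therefore sits within a tight group of values, all within the scatter of one another, so no order can be read from them.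

Compound 4 (`Cc1cccc(C)c1/C=C/[C@](C)(O)CC[C@@H]1[C@@]2(C)CCCC(C)(C)[C@@H]2CC[C@@]1(C)O`) has the same atoms as compound 2, joined differently. It carries 2,6-dimethylphenyl in place of 2,3-dimethylphenyl on a double-bonded chain carbon bound to a double-bonded chain carbon. Among the compounds with values here, no compound measured so far carries the 2,6-dimethylphenyl group, so the evidence is indirect.

Three measured steps change the group at this same place (a 1.1-fold lower number from compound 1 to compound 2 (0.05 log units; within the scatter)) (a 1.3-fold lower number from compound 1 to compound 3 (0.13 log units; within the scatter)) (a 1.2-fold lower number from compound 2 to compound 3 (0.08 log units; within the scatter)), and all of them stay within the scatter. On that basis, no shift in either direction beyond the scatter is expected in this assay, and the estimated step is small (a 1.1-fold lower number from compound 2 to compound 4 (0.03 log units; within the scatter)). In this assay the estimate for compound 4 is 3300 nM (expected range from 1700 nM to 6500 nM).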

Compound 4, half-maximal inhibitory concentration: 278 nM
Estimate against measurement, compound 4: 12-fold (1.07 log units) above; the whole stated range lies above it.
By their numbers in this assay, from the lowest: compound 4; then compounds 3, 2 and 1 (each within the scatter of the next).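

In this assay, moving a single methyl group on the phenyl ring gives a 13-fold lower number from compound 2 to compound 4 (1.10 log units; beyond the scatter), even though the atoms stay the same and the counted features of the group do not change, so at this place the arrangement of the two methyl groups matters as well as their identity. The earlier swaps at this place, even the exchange of isoquinolin-4-yl for a phenyl group, all stayed within the scatter and gave no sign of this sensitivity, whereas the 2,6-dimethylphenyl group stands clearly apart from the other two groups, with a 10-fold lower number from compound 3 to compound 4 (1.02 log units; beyond the scatter) and a 14-fold lower number from compound 1 to compound 4 (1.15 log units; beyond the scatter). Nothing measured alongside these cell results explains why this rearrangement has so large an effect.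

The compounds shown leave open whether the stronger inhibition depends on methyl groups specifically or would also appear with other groups in the same arrangement, such as 2,6-dimethoxyphenyl or 2,6-dichlorophenyl. They also leave open whether both methyl groups are needed, which a comparison with 2-methylphenyl could help to settle.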